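The source may hold more compounds than are shown below. What is called first, only, known or untested is meant among the compounds shown, and "the series" means these compounds.

In a functional assay on MGC-803 cells (Homo sapiens) for antiproliferative activity, read by MTT assay, with a stated time of 72 h (on this read-out higher numbers stand for weaker inhibition and lower numbers for stronger inhibition), the measured compounds stand as follows.
Compound 1 `CCCSc1nc(N/N=C/c2ccccc2F)c2nnn(Cc3ccccc3)c2n1` gives > 64000 nM, a limit of the assay.
Compound 2 `CCCSc1nc(N/N=C/c2ccc(Cl)cc2)c2nnn(Cc3ccccc3)c2n1` gives > 64000 nM, likewise a limit of the assay.
Compound 3 `CCCSc1nc(N/N=C(\C)c2ccccc2O)c2nnn(Cc3cccc(Cl)c3)c2n1` gives 6500 nM.

Compound 2 thus stands only at a limit in this assay, with no number. Compound 1 also stands at a limit. Only compound 3 gives a number. Within the data shown here, the single one-place step, a step that the two limits leave unreadable from compound 1 to compound 2, cannot be read, since both its ends sit at the limit of > 64000 nM in this assay, at which 2 of the 3 values shown sit. Compound 4 `CCCSc1nc(N/N=C/c2cccnc2)c2nnn(Cc3ccccc3)c2n1` differs from compound 2 by pyridin-3-yl in place of 4-chlorophenyl on a carbon with a double bond to nitrogen. Among the measured compounds shown here, no measured step bears on this change, so compound 4 is expected to stay near where compound 2 sits, with the step of an at least 1.0-fold lower number from compound 2 to compound 4 (0.02 log units; that floor lies within the scatter) estimated as nothing beyond the scatter. Compound 4 is estimated at 60000 nM, between 15000 nM and 200000 nM, with a fair chance that only a limit is reported.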

Compound 4, half-maximal inhibitory concentration: 38100 nM
Estimate against measurement, compound 4: 1.6-fold (0.20 log units) above; the range from low to high includes it.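

In this assay, among these compounds, pyridin-3-yl on this carbon with a double bond to nitrogen gives a number rather than a limit, the first for a compound with the benzyl group of compound 1. Against the 4-chlorophenyl group the change gives an at least 1.6-fold lower number from compound 2 to compound 4 (0.22 log units; that floor lies within the scatter), and against the 2-fluorophenyl group it gives an at least 1.6-fold lower number from compound 1 to compound 4 (0.22 log units; that floor lies within the scatter). Compound 1 and compound 2 each remain at a limit of the assay, so the true size of both steps stays unfixed: the limit of > 64000 nM in this assay, at which 2 of the 4 values shown sit.

On these data alone, whether pyridin-4-yl or pyridin-2-yl would behave like pyridin-3-yl here remains open. Compound 3 differs from compound 4 in more than one place and cannot be compared with it.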